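A few compounds are considered here, and "the series" means these few. Any claim that something is new, unique, unknown or untested is made for them only; others in the source may bear on it.

Within the data shown here, in a functional assay on K562 cells (Homo sapiens) for antiproliferative activity, read by MTT assay, with a stated time of 48 h (on this read-out higher numbers stand for weaker inhibition and lower numbers for stronger inhibition), compound 1 (`Cn1cc(C2=C(c3nn(CCCN4CCCCC4)c4ncccc34)C(=O)N(c3cccc4ccccc34)C2=O)c2ccccc21`) gives 3180 nM and compound 2 (`Cn1cc(C2=C(c3nn(CCCN4CCCCC4)c4ncccc34)C(=O)NC2=O)c2ccccc21`) gives 5960 nM, so the only two numbers so far lie within the scatter of each other. Compound 3 (`COc1ccc(N2C(=O)C(c3cn(C)c4ccccc34)=C(c3nn(CCCN4CCCCC4)c4ncccc34)C2=O)cc1`) carries 4-methoxyphenyl in place of hydrogen on an amide-type nitrogen in a ring, that is, 4-methoxyphenyl in place of hydrogen on an amide-type nitrogen in a ring. Among the measured compounds shown here, one measured step bears on this nitrogen: a 1.9-fold higher number from compound 1 to compound 2 (0.27 log units; within the scatter), where hydrogen took the place of naphthalen-1-yl. The expected step in this assay is therefore small, toward stronger inhibition and inside the scatter, estimated as a 1.6-fold lower number from compound 2 to compound 3 (0.20 log units; within the scatter). Compound 3 is estimated at 3800 nM, with an expected range of 1500 nM to 9000 nM.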

Compound 3, half-maximal inhibitory concentration: > 100000 nM
Compound 3 ended at the assay's limit; the forecaster's own chance of this, stated with the estimate: 5%; middle value at least 26-fold (1.42 log units) from the limit.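

The value of compound 3 is a limit and not a number: the limit of > 100000 nM in this assay, at which 1 of the 3 values shown sits. This nitrogen is far from indifferent to what it carries, since 4-methoxyphenyl brings an at least 16-fold higher number from compound 2 to compound 3 (1.22 log units; beyond the scatter), and replacing naphthalen-1-yl with it brings an at least 31-fold higher number from compound 1 to compound 3 (1.49 log units; beyond the scatter). An aromatic ring here does not by itself decide the outcome, as compound 1, with naphthalen-1-yl, stays within the scatter of compound 2, with hydrogen.

The compounds shown do not tell whether the methoxy group or the phenyl ring matters more. A plain phenyl group or a benzyl group on this nitrogen would separate the two.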